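A few compounds are considered here, and "the series" means these few. Any claim that something is new, unique, unknown or untested is made for them only; others in the source may bear on it.

Measured in a functional assay on DU-145 cells (Homo sapiens) for inhibition, read by trypan blue exclusion, with a stated time of 96 h; on this read-out higher numbers stand for weaker inhibition of growth and lower numbers for stronger inhibition of growth:

- compound 1 `Cc1cc(C)cc(/C=C(/SCc2ccc(F)cc2)C(=O)c2ccc(Br)cc2)c1`: 10000 nM
- compound 2 `O=C(/C(=C\c1ccc(O)c([N+](=O)[O-])c1)SCc1ccccc1Cl)c1ccc(Cl)cc1`: 10000 nM

Going by the values given here, compound 1 gives 10000 nM and so stands level with compound 2, the only other measured compound, which gives 10000 nM. The next compound to be tested is compound 3 `O=C(/C(=C\c1c[nH]c2ccc(Cl)cc12)SCc1ccc(F)cc1)c1ccc(Br)cc1`. It comes from compound 1 by placing 5-chloro-1H-indol-3-yl in place of 3,5-dimethylphenyl on a double-bonded chain carbon bound to a double-bonded chain carbon. Among the compounds with values here, no measured pair shows what this exchange does, so the expectation is tentative. In this assay the expected change, towards stronger inhibition of growth, is estimated as a 3.3-fold lower number from compound 1 to compound 3 (0.52 log units; beyond the scatter), and a result within the scatter would not be surprising. For compound 3 the estimated value is 3000 nM, with an expected range from 300 nM to 12000 nM.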

Compound 3, concentration for 50% growth inhibition: 1000 nM
The estimate for compound 3 lay 3.0-fold (0.48 log units) above the measured number, within the range that was stated.
By their numbers in this assay, from the lowest: compound 3; then compounds 1 and 2 (each within the scatter of the next).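

In this assay, placing 5-chloro-1H-indol-3-yl in place of 3,5-dimethylphenyl on a double-bonded chain carbon bound to a double-bonded chain carbon gives a 10-fold lower number from compound 1 to compound 3 (1.00 log units; beyond the scatter). Going by these compounds alone, this is the first single-place change that can be read, and it shows that the group at this position affects inhibition of growth. Nothing available explains the shift.

The exchange alters several things at once, adding a five-membered aromatic ring, a chlorine and a hydrogen-bond donor, so the compounds shown do not assign the shift to any one of them. As far as these compounds go, it remains open whether the shift would survive a methoxy group in place of the chlorine, or a methyl group in place of the hydrogen on the ring nitrogen.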